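Cutting the side chain of compound 1 back to methyl

The compounds below may be only part of what the source reports. "The series", "measured", "known", "first", "only" and "open" are said of these compounds alone.

In a functional assay on A549 cells (Homo sapiens) for cytotoxicity, read by MTT assay, with a stated time of 72 h (a higher number here means a weaker inhibitor, a lower number a stronger inhibitor), compound 1 `COc1ncc(-c2ccc3nc(NC(=O)NCCN4CCCCC4)nn3c2)cc1NS(=O)(=O)c1ccc(F)cc1` gives 610 nM, and compound 2 `CCN(CC)CCNC(=O)Nc1nc2ccc(-c3cnc(OC)c(NS(=O)(=O)c4ccc(Cl)cc4)c3)cn2n1` gives 680 nM. For the measured compounds named here, these two values lie within the scatter of each other, so compound 1 stands level with the only other measured compound.

Compound 3 `CNC(=O)Nc1nc2ccc(-c3cnc(OC)c(NS(=O)(=O)c4ccc(F)cc4)c3)cn2n1` is the next case. Its difference from compound 1 is hydrogen in place of (piperidin-1-yl)methyl on a saturated chain carbon bound to an amide-type nitrogen, so that 2-(piperidin-1-yl)ethyl becomes methyl. Going by the values given here, no measured pair isolates this change, and no measured compound carries the methyl group, so the size of the step remains a judgement. A moderate move toward a higher number, meaning a weaker inhibitor, is expected, with wide uncertainty. The estimated step is a 2.5-fold higher number from compound 1 to compound 3 (0.39 log units; beyond the scatter). For compound 3 the expected value is 1500 nM, with an estimated range of 300 nM to 7000 nM.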

Compound 3, half-maximal inhibitory concentration: 230 nM
Beside the measured number, compound 3's estimate is 6.5-fold (0.81 log units) above it; the measured number lies below the stated range.
By their numbers in this assay, from the lowest: compound 3; then compounds 1 and 2 (each within the scatter of the next).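

In this assay, hydrogen in place of (piperidin-1-yl)methyl on a saturated chain carbon bound to an amide-type nitrogen gives a 2.7-fold lower number from compound 1 to compound 3 (0.42 log units; beyond the scatter) and thus a modest gain. Compounds 1 and 2 stood level and could not be compared in one place, whereas this pair shows that the 2-(piperidin-1-yl)ethyl chain is not needed at this position for this read-out, and that methyl gives the lower number here. No measurement available bears on the reason for the step.

Going by these compounds, whether the gain belongs to methyl itself or extends to other small groups remains open, with ethyl, cyclopropyl and 2-methoxyethyl as untested comparisons in these compounds. Also open, on these data alone, is whether the same cut would hold for compound 2, whose 2-(diethylamino)ethyl chain sits on a chlorine-bearing sulfonamide.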